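This account rests on a few compounds, and the source may have more. Where it says the series, first, only, none or still open, it means among the compounds named here.

Notes on a series that shares one core and varies the group on a ring amine nitrogen. In a functional assay on HCT-116 cells (Homo sapiens) for antiproliferative activity, read by CCK-8 assay, with a stated time of 72 h (on this read-out lower numbers stand for stronger inhibition and higher numbers for weaker inhibition), compound 1 (`CCOc1cc(C(C)(C)C)ccc1C1=NC(c2ccc(Cl)cc2)C(c2ccc(Cl)cc2)N1C(=O)N1CCN(CCCCCC(=O)NO)CC1`) gives 4030 nM and compound 2 (`CCOc1cc(C(C)(C)C)ccc1C1=NC(c2ccc(Cl)cc2)C(c2ccc(Cl)cc2)N1C(=O)N1CCN(CCCCC(=O)NO)CC1`) gives 5210 nM on the same read-out. Compound 3 (`CCOc1cc(C(C)(C)C)ccc1C1=NC(c2ccc(Cl)cc2)C(c2ccc(Cl)cc2)N1C(=O)N1CCN(c2ncc(C(=O)NO)cn2)CC1`) stands lowest of the three at 980 nM in this assay.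

Compound 4 (`CCOc1cc(C(C)(C)C)ccc1C1=NC(c2ccc(Cl)cc2)C(c2ccc(Cl)cc2)N1C(=O)N1CCN(CCCCCCCC(=O)NO)CC1`) differs from compound 3 as follows: 7-(hydroxycarbamoyl)heptyl in place of 5-(hydroxycarbamoyl)pyrimidin-2-yl on an amine nitrogen in a ring.

Two measured steps go from a chain to the pyrimidine group, a 4.1-fold lower number from compound 1 to compound 3 (0.61 log units; beyond the scatter) and a 5.3-fold lower number from compound 2 to compound 3 (0.73 log units; beyond the scatter) and both are modest and beyond the scatter. The step between the two chains, a 1.3-fold higher number from compound 1 to compound 2 (0.11 log units; within the scatter) stays within the scatter, so chain length offers no trend, and no heptyl chain has been measured.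

The change to compound 4 runs the opposite way, so a modest step to a higher number of similar size is expected in this assay here. The estimated step is a 3.9-fold higher number from compound 3 to compound 4 (0.59 log units; beyond the scatter) on this reasoning. Compound 4 is estimated at 3800 nM with an expected range of 1600 nM to 8500 nM in this assay.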

Compound 4, half-maximal inhibitory concentration: 1710 nM
Estimate against measurement, compound 4: 2.2-fold (0.35 log units) above; low and high end bracket the measured number.
By their numbers in this assay, from the lowest: compounds 3 and 4 (each within the scatter of the next); then compounds 1 and 2 (each within the scatter of the next).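

With the group on the ring amine nitrogen as 7-(hydroxycarbamoyl)heptyl, a 1.7-fold higher number from compound 3 to compound 4 (0.24 log units; within the scatter) stays within the scatter in this assay, so an open chain without any ring can read level with the 5-(hydroxycarbamoyl)pyrimidin-2-yl group. Chain length, flat between the earlier chains, now shows an effect, with a 3.0-fold lower number from compound 2 to compound 4 (0.48 log units; beyond the scatter) and a 2.4-fold lower number from compound 1 to compound 4 (0.37 log units; beyond the scatter) both lying beyond the scatter. This is no steady trend with length, since compounds 1 and 2 stay within the scatter of each other and only the heptyl chain separates from them.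

As far as these compounds go, whether a longer chain would keep the number at this level or lower it, and how a carboxylic acid would read in place of the hydroxycarbamoyl end, remains open. Nothing at hand explains the differences among these four compounds.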